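The source may hold more compounds than are shown below. What is called first, only, known or untested is meant among the compounds shown, and "the series" means these compounds.

Measured so far:
- compound 1 `C=C1CC[C@@H]2[C@](C)(COC(C)=O)[C@H](OC(C)=O)CC[C@@]2(C)[C@@H]1/C=C/C1=CCOC1=O`: 757000 nM
- compound 2 `C=C1CC[C@@H]2[C@](C)(CO)[C@H](OC(C)=O)CC[C@@]2(C)[C@@H]1C/C=C1\C=COC1=O`: 872000 nM

In an ADME assay on HepG2 2.2.15 cells (Homo sapiens) for cytotoxicity, read by MTT assay (on this read-out higher numbers stand for lower toxicity in this test and lower numbers for higher toxicity in this test), compound 2 at 872000 nM lies within the scatter of compound 1 at 757000 nM. Compound 3 `C=C1CC[C@@H]2[C@](C)(COC(C)=O)[C@H](OC(C)=O)CC[C@@]2(C)[C@@H]1C/C=C1\C=COC1=O` differs from compound 2 by acetyl in place of hydrogen on an oxygen on a saturated carbon, with acetyl in place of hydrogen on an oxygen on a saturated carbon, hydroxymethyl to acetoxymethyl. For the measured compounds named here, no measured pair shows this change alone, so no step beyond the scatter is expected in this assay, and no direction is favoured. The expected change is a 1.2-fold lower number from compound 2 to compound 3 (0.07 log units; within the scatter). Compound 3 is estimated at 750000 nM, with an expected range of 350000 nM to 1400000 nM.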

Compound 3, half-maximal cytotoxic concentration: 297000 nM
Estimate against measurement, compound 3: 2.5-fold (0.40 log units) above; the whole stated range lies above it.
By their numbers in this assay, from the lowest: compound 3; then compounds 1 and 2 (each within the scatter of the next).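

Acetyl in place of hydrogen on this oxygen, hydroxymethyl to acetoxymethyl, gives a 2.9-fold lower number from compound 2 to compound 3 (0.47 log units; beyond the scatter) in this assay and is the first change in the series with a step beyond the scatter. Acetoxymethyl alone does not set the number, since compound 1 also carries it, and the exchange of the group of 8 heavy atoms on a saturated ring carbon gives a 2.5-fold lower number from compound 1 to compound 3 (0.41 log units; beyond the scatter) in this assay as well. Nothing measured bears on the cause of either step. As far as these compounds go, whether a longer acyl chain or a benzoyl group on this oxygen moves the number further remains open.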